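Series notes: sulfonyl aryl swap and growth inhibition

The compounds below may be only part of what the source reports. "The series", "measured", "known", "first", "only" and "open" are said of these compounds alone.

Measured so far:
compound 1 `CC(=O)Nc1ccc(S(=O)(=O)NNC(=O)c2cccnc2Nc2ccc(Cl)cc2)cc1` — > 100000 nM
compound 2 `O=C(NNS(=O)(=O)c1ccc(F)cc1)c1cccnc1Nc1ccc(Cl)cc1Cl` — > 100000 nM

In a functional assay on U-251 cells (Homo sapiens) for antiproliferative activity (on this read-out lower numbers stand for stronger inhibition of growth and higher numbers for weaker inhibition of growth), compound 1 gives > 100000 nM, which is a limit of the assay and not a number. Compound 2 gives > 100000 nM in this assay, again only a limit. Both shown values sit at the same ceiling (the limit of > 100000 nM in this assay, at which 2 of the 2 values shown sit), so no step between measured compounds can be read and nothing places compound 1 anywhere but at that ceiling.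

Compound 3 `O=C(NNS(=O)(=O)c1ccc(Cl)cc1Cl)c1cccnc1Nc1ccc(Cl)cc1` is to be measured in this assay. Its change from compound 1 is 2,4-dichlorophenyl in place of 4-acetamidophenyl on a sulfonyl sulfur. With compound 1 at a limit, the data give no direction for this change. The expected step from compound 1 to compound 3 is a step that the limit leaves unreadable from compound 1 to compound 3, meaning no movement beyond the scatter is expected and a further limit read-out is the most likely outcome. Compound 3 is estimated at 150000 nM, with a range from 30000 nM to 600000 nM.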

Compound 3, concentration for total growth inhibition: 100000 nM
Beside the measured number, compound 3's estimate is 1.5-fold (0.18 log units) above it; low and high end bracket the measured number.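

In this assay, 2,4-dichlorophenyl in place of 4-acetamidophenyl on a sulfonyl sulfur gives a number no higher from compound 1 to compound 3 (the limit leaves the size open), so this position now has a direction for this change, though no size. Compound 3 gives 100000 nM, the first read-out in the series that is a number and not a limit. That number stands right at the ceiling of the assay, so it marks only the very start of a readable range: the limit of > 100000 nM in this assay, at which 2 of the 3 values shown sit.

The size of the step cannot be read, and the compounds shown do not separate the arrival of the two chlorines from the loss of the acetamide. Going by these compounds, how a phenyl carrying an amine or a carboxylic acid would read on a sulfonyl sulfur also stays open.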